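From isopropyl to cyano on a shared core

This account rests on a few compounds, and the source may have more. Where it says the series, first, only, none or still open, it means among the compounds named here.

Measured so far:
- compound 1 (`CCc1ncncc1-c1nc2cc(F)c(F)cc2n1C1CC1`): 78%
- compound 2 (`CC(C)c1ncncc1-c1nc2cc(F)c(F)cc2n1C1CC1`): 80%

Both numbers come from an ADME assay on microsomes from liver (Macaca fascicularis) for metabolic stability, read by LC-MS, with a stated time of 65 min, tested at 1 uM (a higher number here means that more of the compound is left, a lower number that less of the compound is left), and lie within the scatter of each other, so compound 2 stands level with compound 1 on the evidence so far. Going by the values given here, the only measured step is a number 2 percentage points higher from compound 1 to compound 2 (within the scatter) and it places methyl in place of hydrogen on a saturated chain carbon.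

Compound 3 (`N#Cc1ncncc1-c1nc2cc(F)c(F)cc2n1C1CC1`) has cyano in place of isopropyl on an aromatic carbon, and the full difference from compound 2 can be counted (cyano in place of isopropyl on an aromatic carbon). Among the compounds with values here, no measured compound carries a cyano, so that one small step is only a weak guide and the data favour neither direction. The expectation therefore starts from compound 2 at 80% and foresees no change beyond the scatter in this assay while keeping a wide margin. The expected move is a number 2 percentage points lower from compound 2 to compound 3 (within the scatter) and remains an estimate. The estimate for compound 3 is 78% within an expected range of 58% to 93% for now.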

Compound 3, percent of the compound remaining: 85%
Compound 3: the middle estimate sits 7 percentage points below what was measured, within the range that was stated.
By their numbers in this assay, from the lowest: compounds 1, 2 and 3 (each within the scatter of the next).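

Going by these compounds alone, until now the only comparison at this position was between two saturated chains, ethyl and isopropyl. Compound 3 shows that in this assay this aromatic carbon, next to the ring nitrogen, can carry a very different group: isopropyl, with 3 carbon atoms, leaves, and cyano, with its triple bond and 1 hydrogen-bond acceptor, enters, yet the change is only a number 5 percentage points higher from compound 2 to compound 3 (within the scatter) and the compounds stay level. Set against the ethyl group the picture is the same, at a number 7 percentage points higher from compound 1 to compound 3 (within the scatter), but nothing measured on these compounds offers a reason for this.

All three compounds lie within the scatter of one another, so they do not show whether any group at this position would move the number beyond the scatter. Whether an amine, a carboxylic acid or a longer chain on this carbon would leave as much compound remaining as ethyl, isopropyl and cyano do remains an open question.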